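This account rests on a few compounds, and the source may have more. Where it says the series, first, only, none or still open, it means among the compounds named here.

Measured compounds:
compound 1, `O=C(NCCCNC1CCCCC1)[C@H]1C[C@@H]1c1ccccc1`, 200 nM; 158 nM; 158 nM (3 entries)
compound 2, `CCN(CC)CCNC(=O)[C@H]1C[C@@H]1c1ccccc1`, 126 nM

Going by the values given here, in an assay on CHO cells for displacement of a labelled ligand from Sigma non-opioid intracellular receptor 1 (Homo sapiens), with a stated time of 180 min (a higher number here means a weaker inhibitor, a lower number a stronger inhibitor), compound 2 gives 126 nM, the only number for it; one further entry gives no single number. The repeat spread of this assay is shown by compound 1 in the several entries of compound 1 in this assay, 200 nM; 158 nM; 158 nM (3 entries). Compound 3, `CC(C)N(CCNC(=O)[C@H]1C[C@@H]1c1ccccc1)C(C)C`, is not yet measured in this assay. It differs from compound 2 by diisopropylamino in place of diethylamino on a saturated chain carbon, two bonds along the chain from an amide-type nitrogen. Among the compounds with values here, no measured pair covers such a change, so no step beyond the scatter is expected in either direction. Compound 3 is estimated at 160 nM, range 60 nM to 450 nM. The expected step of a 1.3-fold higher number from compound 2 to compound 3 (0.10 log units; within the scatter) stays within the scatter.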

Compound 3, inhibition constant in the Sigma non-opioid intracellular receptor 1 assay: 63.1 nM
Estimate against measurement, compound 3: 2.5-fold (0.40 log units) above; measured number inside the range.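

In the Sigma non-opioid intracellular receptor 1 assay, diisopropylamino in place of diethylamino gives a 2.0-fold lower number from compound 2 to compound 3 (0.30 log units; within the scatter), so this saturated chain carbon carries seven heavy atoms in the group instead of five with no step beyond the scatter. That reading rests on the repeat spread: the several entries of compound 1 in the Sigma non-opioid intracellular receptor 1 assay, 200 nM; 158 nM; 158 nM (3 entries) In a physicochemical assay for lipophilicity, measured as octanol-water partition, at pH 7.4 (on this read-out lower numbers stand for lower lipophilicity and higher numbers for higher lipophilicity), compound 2 gives 0.6 and compound 3 gives 1 on this read-out. The distribution coefficient does shift with this change, while the binding number stays within the scatter: the measured distribution coefficient of compound 2, 0.6, and of compound 3, 1, a number 0.40 log units higher (beyond the scatter)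

Still open, as far as these compounds go, is how a piperidine ring or a longer chain in place of diisopropylamino would fare in the Sigma non-opioid intracellular receptor 1 assay. One pair cannot tell whether the two read-outs move together across the series.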